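The source may hold more compounds than are shown below. What is called first, only, known or untested is meant among the compounds shown, and "the series" means these compounds.

Within the data shown here, two thiourea compounds measured in a functional assay on B16 cells (Mus musculus) for inhibition, tested at 10 uM (a lower number here means less inhibition, a higher number more inhibition at the concentration tested (going by the name of the read-out)), make up the series so far. Compound 1 `CCc1ccc(NC(N)=S)cc1` gives 88%. Compound 2 `NC(=S)Nc1ccc(O)cc1` gives 70%, the lowest of the two numbers; the step of a number 18 percentage points lower from compound 1 to compound 2 (beyond the scatter) is hydroxy in place of ethyl on an aromatic carbon.

Compound 3 `COc1ccc(NC(N)=S)cc1` is not yet measured. It differs from compound 2 by methyl in place of hydrogen on an oxygen on an aromatic ring, read one bond further out as hydroxy to methoxy. Among the measured compounds shown here, no measured step involves a change on an oxygen on an aromatic ring, so nothing in the data bears directly on this change; the only known step concerns an exchange on the aromatic carbon itself. For the measured compounds named here, with no comparable step to lean on, the expectation for compound 3 is a step of a number 5 percentage points higher from compound 2 to compound 3 (within the scatter), within the scatter, in this assay. Compound 3 is thus estimated at 75%, with a range from 55% to 92%.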

Compound 3, a percentage reported as inhibition, at one concentration (the size of the read-out at that concentration, not a potency): 80%
The estimate for compound 3 lay 5 percentage points below the measured number, within the range that was stated.
By their numbers in this assay, from the lowest: compounds 2, 3 and 1 (each within the scatter of the next, the first and the last beyond it).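

Methyl in place of hydrogen on an oxygen on an aromatic ring, read as hydroxy to methoxy, gives a number 10 percentage points higher from compound 2 to compound 3 (within the scatter) in this assay, so this exchange on the oxygen produces no step that stands clear of the scatter. Swapping the ethyl for a methoxy gives a number 8 percentage points lower from compound 1 to compound 3 (within the scatter), so compound 3 cannot be told apart from either compound 1 or compound 2, although those two differ beyond the scatter. No measurement at hand gives a reason for these numbers.

From the compounds shown here alone, whether a longer chain on the oxygen, such as ethoxy, would keep the number within the scatter of compound 3 stays open. So does the outcome of an amine or a carboxylic acid in place of ethyl on the aromatic carbon.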